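Adding a Methyl to the Amino Group of Compound 2

The compounds below may be only part of what the source reports. "The series", "measured", "known", "first", "only" and "open" are said of these compounds alone.

Compound 2 `Nc1nc(N)c2nc(O)n(Cc3ccccc3)c2n1` gives 10 uM in a functional assay (spleen, spleen) for activation, with Mus musculus as the target (a higher number here means that more compound is needed for the effect, a lower number that less compound is needed), the highest of the two numbers measured; its nearest neighbour, compound 1 `CCCCCOc1nc(N)c2nc(O)n(Cc3ccccc3)c2n1`, gives 0.01 uM in this assay. Within the data shown here, the one measured step, a 1000-fold higher number from compound 1 to compound 2 (3.00 log units; beyond the scatter), shows how much the group at this place can matter. Compound 3 `CNc1nc(N)c2nc(O)n(Cc3ccccc3)c2n1` differs from compound 2 by methyl in place of hydrogen on a nitrogen on an aromatic ring. Among the measured compounds shown here, this small change has no direct precedent here, so only a modest step is expected; because a 1000-fold higher number from compound 1 to compound 2 (3.00 log units; beyond the scatter) ran against the bare amino group, a somewhat lower number is expected for compound 3, namely a 3.3-fold lower number from compound 2 to compound 3 (0.52 log units; beyond the scatter). Compound 3 is estimated at 3 uM, between 0.5 uM and 20 uM.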

Compound 3, minimum effective concentration: 1 uM
The estimate for compound 3 lay 3.0-fold (0.48 log units) above the measured number, and the stated range covers the measured number.
By their numbers in this assay, from the lowest: compound 1; then compound 3; then compound 2.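

A single added methyl on the nitrogen moves the number clearly (a 10-fold lower number from compound 2 to compound 3 (1.00 log units; beyond the scatter)), so even the smallest change at this place counts. Methylamino still falls well short of pentyloxy (a 100-fold higher number from compound 1 to compound 3 (2.00 log units; beyond the scatter)), and this remaining gap is larger than the one the methyl closed. Nothing measured here explains the effect of the methyl. As far as these compounds go, whether a longer chain on the nitrogen, as in pentylamino, would close more of the gap stays open. So does how a shorter ether such as methoxy would compare with pentyloxy.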